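Swapping the aryl group on the triazole nitrogen

This account rests on a few compounds, and the source may have more. Where it says the series, first, only, none or still open, it means among the compounds named here.

Of the compounds shown here, three sharing one core have been tested in a functional assay on PC-12 cells (Rattus norvegicus) for cytotoxicity, read by MTT assay, with stated times of 2 h and 24 h, tested at 1 uM; on this read-out higher numbers stand for a stronger effect at the one concentration tested and lower numbers for a weaker effect. Compound 1 `CC(C)c1ccc(-n2nc(-c3ccc(C(F)(F)F)cc3O)nc2-c2ccccc2O)cc1` gives 69.7%. Compound 2 `Oc1cc(C(F)(F)F)ccc1-c1nc(-c2ccccc2O)n(-c2ccc(F)cc2)n1` gives 67.2%, a number that sits within the usual scatter of both other compounds. Compound 3 `Oc1cc(C(F)(F)F)ccc1-c1nc(-c2ccccc2O)n(-c2ccc(Br)cc2)n1` gives 69.4%. The three steps among them, a number 2.5 percentage points lower from compound 1 to compound 2 (within the scatter), a number 0.3 percentage points lower from compound 1 to compound 3 (within the scatter) and a number 2.2 percentage points higher from compound 2 to compound 3 (within the scatter), all change only the substituent on the phenyl ring attached to the aromatic nitrogen, and none of them moves the read-out beyond the scatter.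

Compound 4 `Oc1cc(C(F)(F)F)ccc1-c1nc(-c2ccccc2O)n(-c2ccccc2Cl)n1` is the next step from compound 2: 2-chlorophenyl in place of 4-fluorophenyl on an aromatic nitrogen. This change again touches only the aryl group on that aromatic nitrogen, the same place varied in the three measured steps, which were all small. Among the measured compounds shown here, no measured step, however, moves a halogen from one ring position to another, so the comparison is only approximate.

The measured steps at this position were all within the scatter. Compound 4 is therefore expected to give about 68%, within a range from 57% to 78%. The estimated step is thus a number 0.8 percentage points higher from compound 2 to compound 4 (within the scatter), no change beyond the scatter.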

Compound 4, a percentage reported as activity, at one concentration (the size of the read-out at that concentration, not a potency): 70.1%
The estimate for compound 4 lay 2.1 percentage points below the measured number, and the stated range covers the measured number.
By their numbers in this assay, from the lowest: compounds 2, 3, 1 and 4 (each within the scatter of the next).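

In this assay the change to 2-chlorophenyl on the aromatic nitrogen gives a number 2.9 percentage points higher from compound 2 to compound 4 (within the scatter) and a number 0.7 percentage points higher from compound 3 to compound 4 (within the scatter) and also a number 0.4 percentage points higher from compound 1 to compound 4 (within the scatter) when measured against the three earlier compounds. Among the compounds shown here, the earlier groups were all 4-substituted phenyl rings, so this is the first sign that a phenyl ring substituted differently, and carrying chlorine, also stays within the scatter at this position. Nothing available explains why the read-out stays so flat across these groups.

On these data alone, all four compounds carry only a halogen or isopropyl on this phenyl ring, so it remains open whether an amine, a carboxylic acid or a longer chain there would move the read-out beyond the scatter. A single tested concentration also leaves open how these compounds compare in potency.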